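This account rests on a few compounds, and the source may have more. Where it says the series, first, only, none or still open, it means among the compounds named here.

In an ADME assay on HepG2 cells (Homo sapiens) for cytotoxicity, read by CellTiter-Glo, with a stated time of 48 h (on this read-out lower numbers stand for higher toxicity in this test and higher numbers for lower toxicity in this test), compound 1 (`CCCCNc1nc2cc(OC)ccc2nc1S(C)(=O)=O`) gives > 100000 nM, which is a limit of the assay and not a number. This places compound 1 at the limit of > 100000 nM in this assay, at which 1 of the 3 values shown sits. Compound 2 (`COc1ccc2nc(S(C)(=O)=O)c(NC3CCCCC3)nc2c1`) gives 79400 nM, and compound 3 (`COc1ccc2nc(S(C)(=O)=O)c(NCCC(C)C)nc2c1`) gives 50100 nM. Compound 4 (`CCCCNc1nc2cc(Cl)ccc2nc1S(C)(=O)=O`) keeps the butyl group of compound 1 but carries chloro in place of methoxy on an aromatic carbon. Among the compounds with values here, no measured step makes this change, since all three alter only the group on the nitrogen. They are therefore indirect guides: an at least 1.2-fold lower number from compound 1 to compound 2 (0.10 log units; that floor lies within the scatter), an at least 1.9-fold lower number from compound 1 to compound 3 (0.30 log units; that floor lies within the scatter) and a 1.6-fold lower number from compound 2 to compound 3 (0.20 log units; within the scatter). Within the data shown here, with steps this small as the only evidence, a modest move towards a lower number is expected, or none beyond the scatter. The expected result is an at least 1.6-fold lower number from compound 1 to compound 4 (0.22 log units; that floor lies within the scatter). For compound 4, the estimated value in this assay is 60000 nM, with an expected range of 20000 nM to 100000 nM.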

Compound 4, half-maximal cytotoxic concentration: 6310 nM
Compound 4: middle estimate off by 9.5-fold (0.98 log units), on the high side, outside the stated range (below it).
By their numbers in this assay, from the lowest: compound 4; then compounds 3 and 2 (each within the scatter of the next). At a limit, above all of these: compound 1.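

Until now, only the group on the nitrogen had changed, and none of those steps was read as beyond the scatter. Changing the aromatic carbon while keeping the butyl group gives the first clear shift in this assay, with chloro in place of methoxy producing an at least 15-fold lower number from compound 1 to compound 4 (1.19 log units; beyond the scatter), towards higher toxicity in this test. This size is only a floor, since compound 1 stands at a limit of the assay and not at a number: the limit of > 100000 nM in this assay, at which 1 of the 4 values shown sits.

Going by these compounds, it remains open whether the same exchange would shift the number similarly with the cyclohexyl of compound 2 or the isopentyl of compound 3 on the nitrogen. Also open, on these data alone, is how plain hydrogen, fluoro, bromo or trifluoromethyl at this aromatic carbon would compare with chloro and methoxy.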